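A 3-methylphenyl swap awaiting its first number

This account rests on a few compounds, and the source may have more. Where it says the series, first, only, none or still open, it means among the compounds named here.

In a functional assay on ACHN cells (Homo sapiens) for inhibition, read by sulforhodamine B assay (on this read-out lower numbers stand for stronger inhibition of growth and higher numbers for weaker inhibition of growth), compound 1 (`O=C(CCC1=CCCN(Cc2ccc(F)cc2)C1=O)NO`) has no number to stand on, and its entry reads ("not determined" (no result reported)). Compound 2 (`CC(=O)Nc1ccc(CN2CCC=C(CCC(=O)NO)C2=O)cc1`) likewise offers no result ("not determined" (no result reported)). Only compound 3 (`COc1ccc(CN2CCC=C(CCC(=O)NO)C2=O)cc1`) yields a figure (1670 nM).

Compound 4 (`Cc1cccc(CN2CCC=C(CCC(=O)NO)C2=O)c1`) departs from compound 1 by a single change (3-methylphenyl in place of 4-fluorophenyl on a saturated chain carbon bound to an amide-type nitrogen in a ring), with 3-methylphenyl in place of 4-fluorophenyl on a saturated chain carbon bound to an amide-type nitrogen in a ring. Among the measured compounds shown here, the data give no value for compound 1 from which to measure this step, and no step between measured compounds is available as a guide. For the measured compounds named here, the only anchor is compound 3 (1670 nM), and compound 4 is expected to lie within the scatter of that figure, with neither direction favoured. In this assay the estimated value for compound 4 is (1600 nM), with an expected range from 500 nM to 5000 nM (a wide span, resting on one measured figure).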

Compound 4, concentration for 50% growth inhibition: 4380 nM
Estimate against measurement, compound 4: 2.7-fold (0.44 log units) below, and the stated range covers the measured number.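

Compound 4 differs from compound 1 in one place, but in this assay compound 1 carries no number, so no step can be read between them. No measured evidence bears on this result. In this assay the compounds shown leave open how 3-methylphenyl and 4-fluorophenyl compare on the shared core.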